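This account rests on a few compounds, and the source may have more. Where it says the series, first, only, none or still open, it means among the compounds named here.

Working notes on the tetrabromo series.

Within the data shown here, compound 1 `OC(CCn1nc2c(Br)c(Br)c(Br)c(Br)c2n1)c1cccc(Br)c1` is the weaker of the two compounds measured so far in a functional assay on CCRF-CEM cells (Homo sapiens) for antiproliferative activity, read by MTT assay, with a stated time of 48 h, tested at 12.5 uM; on this read-out higher numbers stand for a weaker effect at the one concentration tested and lower numbers for a stronger effect: compound 1 gives 118% and stands highest of the two numbers. Compound 2 `C[C@H](O)CCn1nc2c(Br)c(Br)c(Br)c(Br)c2n1` is the nearest point, and in this assay compound 2 gives 92%, a number lower than that of compound 1 by a margin that lies beyond the usual scatter.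

Compound 3 `CC(O)CCn1nc2c(Br)c(Br)c(Br)c(Br)c2n1` has not yet been measured in this assay. It differs from compound 1 in one place: methyl in place of 3-bromophenyl on a saturated chain carbon bound to an oxygen on a saturated carbon and a saturated chain carbon. Among the measured compounds shown here, no step between measured compounds is recorded for this pair, so the size of the change has to be judged from the two values in hand.

The expectation is a step downward in this assay, that is toward a stronger effect, of about a number 26 percentage points lower from compound 1 to compound 3 (beyond the scatter). This is expected because compound 2, the closest measured reference, gives 92%. For compound 3 the estimate in this assay is 92%, within a range from 75% to 110%.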

Compound 3, a percentage reported as activity, at one concentration (the size of the read-out at that concentration, not a potency): 94%
Compound 3: the middle estimate sits 2 percentage points below what was measured; measured number inside the range.
By their numbers in this assay, from the lowest: compounds 2 and 3 (each within the scatter of the next); then compound 1.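

Working from the one place where compounds 1 and 3 differ, methyl in place of 3-bromophenyl on this saturated chain carbon gives the first direct step at this position in this assay, and it runs toward a stronger effect: a number 24 percentage points lower from compound 1 to compound 3 (beyond the scatter). The second step concerns the same carbon and gives a number 2 percentage points higher from compound 2 to compound 3 (within the scatter), so the two methyl compounds cannot be told apart on this read-out, and the size of the first step is matched whichever of them serves as the methyl reference. A drawn S configuration at this stereocentre therefore shows no effect in this assay that stands out from the scatter, though this reading compares a defined drawing with an undefined one and no more: the fact that one of compounds 2 and 3 is drawn with a defined configuration and the other without, at the place where they differ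

The compounds shown leave open what the opposite configuration at this carbon would give, since no compound here is drawn with it. They also leave open whether an unsubstituted phenyl, a longer chain or a carboxylic acid at this carbon would read like methyl or like 3-bromophenyl in this assay.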